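The source may report more compounds than this note shows. Statements on the series, on what has been measured and on what is new or still open speak of the compounds shown alone.

Compound 1, `COc1ccccc1N1CCN(CCCCCC(=O)c2cccc(O)c2)CC1`, gives 26.8 nM in an assay on isolated protein for binding affinity to 5-hydroxytryptamine receptor 7 (Rattus norvegicus); on this read-out lower numbers stand for stronger inhibition and higher numbers for weaker inhibition.
Compound 2, `COc1ccccc1N1CCN(CCCCCC(=O)c2ccccc2O)CC1`, gives 5.8 nM in this assay.
Compound 3, `COc1ccccc1N1CCN(CCCCCC(=O)c2ccc(O)cc2)CC1`, gives 23.7 nM in this assay.

Among these three, compound 2 has the lowest number in this assay, and both of its neighbours lie beyond the scatter: there is a 4.6-fold lower number from compound 1 to compound 2 (0.66 log units; beyond the scatter) and a 4.1-fold higher number from compound 2 to compound 3 (0.61 log units; beyond the scatter), whereas a 1.1-fold lower number from compound 1 to compound 3 (0.05 log units; within the scatter). All three share the same core and differ only in where the hydroxyl sits on the ring attached to the carbonyl.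

Compound 4, `O=C(CCCCCN1CCN(c2nc3ccccc3o2)CC1)c1ccccc1O`, is not yet measured. It departs from compound 2 at the other end of the molecule: 1,3-benzoxazol-2-yl in place of 2-methoxyphenyl on an amine nitrogen in a ring. Going by the values given here, none of the measured steps touches this part of the core; every change recorded so far concerns the hydroxyphenyl group on the carbonyl, so no step tells how this assay responds to a change on the ring nitrogen. The expectation for compound 4 in this assay therefore rests only on its being otherwise identical to compound 2, and it is framed with a wide range. Compound 4 is estimated at 10 nM, expected to fall between 2 nM and 60 nM. This estimate means a 1.7-fold higher number from compound 2 to compound 4 (0.24 log units; within the scatter), a step that is expected to stay close to compound 2 but could go either way.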

Compound 4, inhibition constant: 148 nM
For compound 4 the middle estimate is 15-fold (1.17 log units) below the measured one; the whole stated range lies below it.
By their numbers in this assay, from the lowest: compound 2; then compounds 3 and 1 (each within the scatter of the next); then compound 4.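

Changing the group on the ring nitrogen has a clear effect in this assay: with the 2-hydroxyphenyl carbonyl end held fixed, 1,3-benzoxazol-2-yl in place of 2-methoxyphenyl gives a 26-fold higher number from compound 2 to compound 4 (1.41 log units; beyond the scatter), whereas the biggest step at the hydroxyphenyl end was a 4.6-fold lower number from compound 1 to compound 2 (0.66 log units; beyond the scatter), so this end of the molecule also matters for the read-out. The entering group differs from the leaving one in several ways at once, bringing one more heavy atom, a ring nitrogen, a five-membered aromatic ring with 2 hetero atoms and an additional hydrogen-bond acceptor, and a single pair cannot separate these differences. Nothing available here explains why this change gives the higher number.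

The compounds shown leave open whether the hydroxyl position has the same effect when 1,3-benzoxazol-2-yl sits on the ring nitrogen, as a 3-hydroxyphenyl or 4-hydroxyphenyl partner of compound 4 would show. They also leave open whether a plain phenyl or a 2-pyridyl on that nitrogen would give a number closer to compound 2 or to compound 4.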